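Sulfonyl substituent swaps and passive permeability in one series

The source may report more compounds than this note shows. Statements on the series, on what has been measured and on what is new or still open speak of the compounds shown alone.

Measured so far:
- compound 1, `CC(C)OC(=O)NCCS(=O)(=O)NC(=O)c1ccc(Nc2nc(NC3(c4ccc(Cl)cc4)CC3)nc(OCC(F)(F)F)n2)cc1`, gives 71 nm/s in a physicochemical assay for permeability, using PAMPA, at pH 7.4; a lower number here means that the compound crosses the layer more slowly, a higher number that the compound crosses the layer faster
- compound 2, `CC(C)C(=O)NCCS(=O)(=O)NC(=O)c1ccc(Nc2nc(NC3(c4ccc(Cl)cc4)CC3)nc(OCC(F)(F)F)n2)cc1`, gives 13 nm/s in this assay
- compound 3, `CC(C)S(=O)(=O)NC(=O)c1ccc(Nc2nc(NC3(c4ccc(Cl)cc4)CC3)nc(OCC(F)(F)F)n2)cc1`, gives 31 nm/s in this assay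

Compound 3 stands second highest of the three numbers. The step of a 2.3-fold lower number from compound 1 to compound 3 (0.36 log units; beyond the scatter) places it under compound 1; the step of a 2.4-fold higher number from compound 2 to compound 3 (0.38 log units; beyond the scatter) places it over compound 2.

Compound 4, `CC(=O)NCCS(=O)(=O)NC(=O)c1ccc(Nc2nc(NC3(c4ccc(Cl)cc4)CC3)nc(OCC(F)(F)F)n2)cc1`, differs from compound 3 by 2-acetamidoethyl in place of isopropyl on a sulfonyl sulfur. Within the data shown here, the closest precedent is compound 2, which carries an amide on the same kind of chain, and the change in the reverse sense, a 2.4-fold higher number from compound 2 to compound 3 (0.38 log units; beyond the scatter), was modest. The carbamate analogue, compound 1, went the other way, as a 2.3-fold lower number from compound 1 to compound 3 (0.36 log units; beyond the scatter) shows, so the two steps do not agree on direction. Weighting the amide precedent, a modest downward step is expected for compound 4, a 2.6-fold lower number from compound 3 to compound 4 (0.41 log units; beyond the scatter). Compound 4 is estimated at 12 nm/s, between 5 nm/s and 30 nm/s.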

Compound 4, apparent permeability: 7 nm/s
The estimate for compound 4 lay 1.7-fold (0.23 log units) above the measured number; measured number inside the range.
By their numbers in this assay, from the lowest: compounds 4 and 2 (each within the scatter of the next); then compound 3; then compound 1.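

The step of a 4.4-fold lower number from compound 3 to compound 4 (0.65 log units; beyond the scatter) places 2-acetamidoethyl on the low side of isopropyl on this sulfonyl sulfur, as with the amide chain of compound 2. On the carbonyl carbon of the chain, the step of a 1.9-fold lower number from compound 2 to compound 4 (0.27 log units; within the scatter) separates methyl from isopropyl by no more than the scatter, whereas a 10-fold lower number from compound 1 to compound 4 (1.01 log units; beyond the scatter) sets methyl well under isopropoxy, leaving compound 1 as the exception among the chain compounds. No measurement shown here explains these differences.

Still open, as far as these compounds go, is whether methoxy or tert-butoxy on that carbonyl carbon would track compound 1. From the compounds shown here alone, a longer chain or a terminal amine or carboxylic acid on the sulfonyl sulfur also remains untested by these compounds.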